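This account rests on a few compounds, and the source may have more. Where it says the series, first, only, none or still open, it means among the compounds named here.

In a functional assay on A549 cells (Homo sapiens) for inhibition (a higher number here means a weaker inhibitor of growth, a lower number a stronger inhibitor of growth), compound 1 `CN(c1ccccc1)S(=O)(=O)c1ccc(C(C)(C)C)cc1` gives 30000 nM. Compound 2 `Cc1ccc(NS(=O)(=O)c2ccc([N+](=O)[O-])cc2)cc1O` gives 29000 nM in this assay, and compound 3 `COc1ccc(S(=O)(=O)Nc2ccc(C)c(O)c2)cc1` gives 51000 nM. Compound 3 thus sits alongside the other two: none of the three numbers differs from another by more than the usual scatter of repeated measurements, so no order among them can be read. One change between measured compounds is on record, the step of a 1.8-fold higher number from compound 2 to compound 3 (0.25 log units; within the scatter), a methoxy in place of a nitro on an aromatic carbon, and it stayed within the scatter. Compound 4 `Cc1ccc(NS(=O)(=O)c2ccc(I)cc2)cc1O` arises from compound 3 by iodo in place of methoxy on an aromatic carbon. Among the measured compounds shown here, the step from compound 2 to compound 3 is a change of the same kind, a swap of one group on an aromatic carbon, and it is the only measured step that bears here; it moved the number by an amount within the scatter. On that basis no step beyond the scatter is expected in this assay, in either direction. Compound 4 is estimated to give 40000 nM, with a range from 15000 nM to 100000 nM. The expected step of a 1.3-fold lower number from compound 3 to compound 4 (0.11 log units; within the scatter) is therefore small.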

Compound 4, concentration for 50% growth inhibition: 15000 nM
Beside the measured number, compound 4's estimate is 2.7-fold (0.43 log units) above it; measured number inside the range.
By their numbers in this assay, from the lowest: compounds 4, 2, 1 and 3 (each within the scatter of the next, the first and the last beyond it).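

Among the compounds shown here, at this position, on an aromatic carbon para to a large group, a single swap can move the number beyond the scatter: in this assay iodo in place of methoxy brings a 3.4-fold lower number from compound 3 to compound 4 (0.53 log units; beyond the scatter), the first step to pass it, though only a modest one. Iodo in place of nitro brings a 1.9-fold lower number from compound 2 to compound 4 (0.29 log units; within the scatter), which stays within the scatter, so at this position only iodo and methoxy are separated, and nitro cannot be placed in order against either. Nothing measured here accounts for that separation.

Only three groups at this position are shown, so how an amine, a carboxylic acid or a bromo would compare there remains open. On these data alone, whether iodo would bring a similar step on the core of compound 1 also remains open.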